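The source may hold more compounds than are shown below. What is called first, only, known or untested is meant among the compounds shown, and "the series" means these compounds.

Compounds measured so far:
- compound 1 `CC1(C)CCC(C)(C)c2cc(-c3cccc(-c4ccc(C(=O)O)cc4)c3)ccc21`, 1 nM
- compound 2 `Cc1ccc(-c2ccc(C(=O)O)cc2)cc1-c1ccc2c(c1)C(C)(C)CCC2(C)C`, 79 nM

In an assay on CV-1 cells (Cercopithecidae) for activation of retinoic acid receptor alpha (Homo sapiens) (on this read-out higher numbers stand for an effect only at larger amounts of compound and lower numbers for an effect already at smaller amounts), compound 2 stands highest of the two numbers, its nearest neighbour being compound 1 at a much lower number. Compound 3 `Cc1ccc(-c2ccc(C(=O)O)cc2)cc1-c1cc2c(cc1C)C(C)(C)CCC2(C)C` differs from compound 2 by methyl in place of hydrogen on an aromatic carbon. For the measured compounds named here, one measured step bears on this change: a 79-fold higher number from compound 1 to compound 2 (1.90 log units; beyond the scatter), which was large. A second methyl on an aromatic carbon, here ortho to a large group, is therefore expected to move the number further upward, though less sharply than that first step. Compound 3 is estimated at 400 nM (range 100 nM to 2000 nM), a step of a 5.1-fold higher number from compound 2 to compound 3 (0.70 log units; beyond the scatter).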

Compound 3, concentration for half-maximal activity: > 1000 nM
Compound 3 gave a limit, no number (the forecaster's own chance of this, stated with the estimate: 10%); middle value at least 2.5-fold (0.39 log units) from the limit.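

In this assay, methyl in place of hydrogen on this aromatic carbon, ortho to a large group and part of a fused system of two rings, gives an at least 12-fold higher number from compound 2 to compound 3 (1.10 log units; beyond the scatter). The earlier compounds shown here showed this change only at a different aromatic carbon, so a second carbon now proves just as sensitive to it. Compound 3 stands as a limit, not a number: the limit of > 1000 nM in this assay, at which 1 of the 3 values shown sits.

The compounds shown leave open how fluorine, chlorine or methoxy would read at this carbon. They also leave open what this methyl would do without the methyl of compound 2.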